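Chloro for Methoxy: What to Expect of Compound 4

The source may report more compounds than this note shows. Statements on the series, on what has been measured and on what is new or still open speak of the compounds shown alone.

compound 1 `Fc1ccc(CSc2nnc(-c3ccncc3)n2-c2ccccc2)c(F)c1`: 11400 nM
compound 2 `O=[N+]([O-])c1ccccc1CSc1nnc(-c2ccncc2)n1-c1ccccc1`: a limit, > 50000 nM
compound 3 `COc1ccc(/C=N/NC(=O)CSc2nnc(-c3ccncc3)n2-c2ccccc2)cc1`: 19200 nM

In a functional assay on HCT-116 cells (Homo sapiens) for inhibition, read by MTT assay, with a stated time of 48 h (a lower number here means a stronger inhibitor, a higher number a weaker inhibitor), compound 3 and compound 1 sit within the usual scatter of each other, so neither can be ranked above the other. For compound 2 this assay reports only a limit, (the limit of > 50000 nM in this assay, at which 1 of the 3 values shown sits).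

Compound 4 `O=C(CSc1nnc(-c2ccncc2)n1-c1ccccc1)N/N=C/c1ccc(Cl)cc1` differs from compound 3 by chloro in place of methoxy on an aromatic carbon. Among the measured compounds shown here, the one measured step, an at least 4.3-fold higher number from compound 1 to compound 2 (0.64 log units; beyond the scatter), concerns a different place on the shared core, a group on a saturated chain carbon bound to a sulfur, and does not touch the aromatic carbon changed here. For the measured compounds named here, no measured step bears on the chloro-for-methoxy exchange. The expectation is therefore no step beyond the scatter, a 1.0-fold lower number from compound 3 to compound 4 (0.00 log units; within the scatter). Compound 4 is estimated at 19000 nM in this assay, with a range from 7500 nM to 48000 nM.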

Compound 4, half-maximal inhibitory concentration: 5740 nM
Beside the measured number, compound 4's estimate is 3.3-fold (0.52 log units) above it; the whole stated range lies above it.
By their numbers in this assay, from the lowest: compounds 4, 1 and 3 (each within the scatter of the next, the first and the last beyond it). At a limit, above all of these: compound 2.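

The earlier compounds shown here showed a step only at the group on a saturated chain carbon bound to a sulfur. In this assay, a 3.3-fold lower number from compound 3 to compound 4 (0.52 log units; beyond the scatter) shows that the aromatic carbon para to a large group also responds to a single exchange, chloro in place of methoxy. Nothing measured here accounts for this modest step.

The compounds shown leave open whether bromo, an amine or a carboxylic acid on this aromatic carbon would move the number further. From the compounds shown here alone, it also remains open whether chloro would give a similar step elsewhere on this ring.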